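Indazole series: ethynyl added to the benzylic alcohol compound

The compounds below may be only part of what the source reports. "The series", "measured", "known", "first", "only" and "open" are said of these compounds alone.

Measured so far: compound 1 `Cc1cc([Si](C)(C)C)c2cn[nH]c2c1` gives 1700 nM; compound 2 `C[Si](C)(C)c1cccc2[nH]ncc12` gives 43000 nM; compound 3 `OC(Cc1ccccc1)c1cccc2[nH]ncc12` gives 7900 nM in an assay for binding affinity to Indoleamine 2,3-dioxygenase 1 (Homo sapiens), read by spectrophotometry, with a stated time of 30 min; a lower number here means tighter binding, a higher number weaker binding.

Compound 3 stands second highest of the three numbers in this assay, below compound 2 and above compound 1. Compound 4 `C#Cc1cc(C(O)Cc2ccccc2)c2cn[nH]c2c1` differs from it by ethynyl in place of hydrogen on an aromatic carbon. Among the compounds with values here, the one measured step that bears on a small group entering or leaving an aromatic carbon of the shared core is a 25-fold higher number from compound 1 to compound 2 (1.40 log units; beyond the scatter), a large move; the present change runs the other way, adding a group. Within the data shown here, a sizeable drop in the number is therefore expected, though the hydroxyl-bearing compounds give no direct precedent. The estimate for compound 4 is 800 nM (range 250 nM to 2500 nM), a step of a 9.9-fold lower number from compound 3 to compound 4 (0.99 log units; beyond the scatter).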

Compound 4, dissociation constant: 1300 nM
For compound 4 the middle estimate is 1.6-fold (0.21 log units) below the measured one; measured number inside the range.
By their numbers in this assay, from the lowest: compounds 4 and 1 (each within the scatter of the next); then compound 3; then compound 2.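

In this assay ethynyl on this aromatic carbon gives a 6.1-fold lower number from compound 3 to compound 4 (0.78 log units; beyond the scatter) and so lowers the number in a compound carrying the benzylic alcohol side chain. Within the data shown here, until now the only step at this carbon was the silyl pair, where loss of methyl gave a 25-fold higher number from compound 1 to compound 2 (1.40 log units; beyond the scatter) as the reverse kind of change. Nothing at hand explains the step.

Still open, as far as these compounds go, is whether methyl on this carbon of compound 3 would match ethynyl. Also open, from the compounds shown here alone, is whether a nitrile, an amine or a longer chain here would lower the number too.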